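From a Phenyl to a Thiophene: Stability of Compound 4

A few compounds are considered here, and "the series" means these few. Any claim that something is new, unique, unknown or untested is made for them only; others in the source may bear on it.

Compound 1 `CCCCCCCCc1ccc(OCC(=O)Cn2nnc(-c3ccccc3)n2)cc1` is the starting point. In an ADME assay on S9 fraction from liver (Rattus norvegicus) for metabolic stability, read by LC-MS, using NADPH, with a stated time of 30 min (on this read-out higher numbers stand for a more stable compound and lower numbers for a less stable compound), compound 1 gives 33%. Two neighbours differ from it in one place. Compound 2 `CCCCCCCCc1ccc(OCC(=O)Cn2nnc(-c3ccc(C(=O)OC)cc3)n2)cc1` gives 64%, and the step of a number 31 percentage points higher from compound 1 to compound 2 (beyond the scatter) is methoxycarbonyl in place of hydrogen on an aromatic carbon. Compound 3 `CCCCCCCCc1ccc(OCC(=O)Cn2nnc(-c3cccc(S(=O)(=O)N(C)C)c3)n2)cc1` gives 9%, and the step of a number 24 percentage points lower from compound 1 to compound 3 (beyond the scatter) is dimethylsulfamoyl in place of hydrogen on an aromatic carbon. Compounds 2 and 3 are separated by a number 55 percentage points lower from compound 2 to compound 3 (beyond the scatter). Compound 1 thus stands second highest of the three numbers, with compound 3 lower and compound 2 higher.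

Compound 4 `CCCCCCCCc1ccc(OCC(=O)Cn2nnc(-c3cccs3)n2)cc1` is not yet measured. It differs from compound 1 as follows: thiophen-2-yl in place of phenyl on an aromatic carbon. Going by the values given here, no measured step exchanges the whole phenyl; the two measured steps from compound 1 only add a group to it, and they run in opposite directions. The exchange of the ring is therefore expected to give a modest step in this assay or none beyond the scatter, a number 3 percentage points lower from compound 1 to compound 4 (within the scatter). Compound 4 is expected to give about 30%, in the range 10% to 55%.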

Compound 4, percent of the compound remaining: 8%
Compound 4: middle estimate off by 22 percentage points, on the high side; measured number outside the range, below it.
By their numbers in this assay, from the lowest: compounds 4 and 3 (each within the scatter of the next); then compound 1; then compound 2.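

In this assay, exchanging the ring itself, with no group added to it, is enough to move the number well beyond the scatter: thiophen-2-yl in place of phenyl gives a number 25 percentage points lower from compound 1 to compound 4 (beyond the scatter). Thiophen-2-yl reads level with 3-(dimethylsulfamoyl)phenyl, a number 1 percentage points lower from compound 3 to compound 4 (within the scatter), and far from 4-(methoxycarbonyl)phenyl, a number 56 percentage points lower from compound 2 to compound 4 (beyond the scatter), so among these four compounds only the last of these groups stands above the plain phenyl. Nothing available here explains why this ring exchange goes with a lower number.

From the compounds shown here alone, it remains open whether the sulfur or the smaller ring size goes with the change, which a furan or a pyridine ring at the same place could help to separate. Going by these compounds, it is equally open whether a methoxycarbonyl group or a carboxylic acid on the thiophene would raise the number.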